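The source may hold more compounds than are shown below. What is called first, only, known or untested is meant among the compounds shown, and "the series" means these compounds.

Among the compounds with values here, in a toxicity assay on MT4 cells (Homo sapiens) for cytotoxicity, read by MTT assay, with a stated time of 5 days (a lower number here means that less compound is tolerated, a higher number that more compound is tolerated), only two related compounds have numbers so far. Compound 1 `Cc1cnc(Nc2ccc(C#N)cc2)nc1Nc1c(F)cc(-c2cncc(C#N)c2)cc1F` gives 50000 nM and compound 2 `Cc1cc(-c2cccs2)cc(C)c1Nc1ccnc(Nc2ccc(C#N)cc2)n1` gives 10000 nM there, so compound 2 holds the lower of the two numbers, by a gap beyond the usual scatter. Compound 3 `Cc1cc(-c2ccc3cc[nH]c3c2)cc(C)c1Nc1ccnc(Nc2ccc(C#N)cc2)n1` keeps the rest of compound 2 but carries 1H-indol-6-yl in place of thiophen-2-yl on an aromatic carbon. Within the data shown here, no measured pair isolates a change like this one, so the data give no direct guide to its size. Taking compound 2 at 10000 nM as the starting point, a small step in this assay toward a lower number is expected, perhaps none beyond the scatter. An estimated 1.3-fold lower number from compound 2 to compound 3 (0.10 log units; within the scatter) is what this expectation amounts to. Compound 3 is estimated at 8000 nM with an expected range from 2500 nM to 25000 nM on repeated measurement.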

Compound 3, half-maximal cytotoxic concentration: 5800 nM
For compound 3 the middle estimate is 1.4-fold (0.14 log units) above the measured one, and the stated range covers the measured number.
By their numbers in this assay, from the lowest: compounds 3 and 2 (each within the scatter of the next); then compound 1.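

In this assay, within the data shown here, putting 1H-indol-6-yl in place of thiophen-2-yl on this aromatic carbon gives a 1.7-fold lower number from compound 2 to compound 3 (0.24 log units; within the scatter) in the first pair of compounds here that differ in one place. The entering group adds a six-membered aromatic ring of carbon only and a hydrogen-bond donor, yet the two numbers cannot be told apart, so in this pair the larger group leaves no readable mark on how much compound the cells tolerate. Nothing measured here explains this result.

A single pair cannot show how an open-chain group, such as an amine or a carboxylic acid on a short carbon chain, would read at this same carbon. It also leaves open whether the same exchange would read alike on the core of compound 1.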